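Methoxy for methyl, repeated on the benzyl group

The source may report more compounds than this note shows. Statements on the series, on what has been measured and on what is new or still open speak of the compounds shown alone.

The shared core of compound 1 `Cc1ccc(-c2ccc3c(c2)C(=O)C(=O)N3)cc1` carries a 4-methylphenyl group; in a functional assay on K562 cells (Homo sapiens) for antiproliferative activity, read by MTT assay, with a stated time of 48 h (a higher number here means a weaker inhibitor, a lower number a stronger inhibitor), compound 1 gives only a limit, > 10000 nM (the limit of > 10000 nM in this assay, at which 1 of the 3 values shown sits). Compound 2 `COc1ccc(-c2ccc3c(c2)C(=O)C(=O)N3)cc1` differs by methoxy in place of methyl on an aromatic carbon and in this assay compound 2 gives 6920 nM; the step is an at least 1.4-fold lower number from compound 1 to compound 2 (0.15 log units; that floor lies within the scatter). Compound 3 `COc1ccc(-c2ccc3c(c2)C(=O)C(=O)N3Cc2ccc(C)cc2)cc1` adds a 4-methylbenzyl group and in this assay compound 3 gives 270 nM, a step of a 26-fold lower number from compound 2 to compound 3 (1.41 log units; beyond the scatter). The difference between the cores of compound 1 and compound 3 is not broken down here. Compound 4 `COc1ccc(CN2C(=O)C(=O)c3cc(-c4ccc(OC)cc4)ccc32)cc1` repeats the same change, (methoxy in place of methyl on an aromatic carbon), now on the core of compound 3. Because the earlier step of an at least 1.4-fold lower number from compound 1 to compound 2 (0.15 log units; that floor lies within the scatter) sits at a floor within the scatter, only a small step of a 1.4-fold lower number from compound 3 to compound 4 (0.13 log units; within the scatter) is expected in this assay. Compound 4 is estimated at 200 nM, expected between 80 nM and 500 nM.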

Compound 4, half-maximal inhibitory concentration: 30 nM
For compound 4 the middle estimate is 6.7-fold (0.82 log units) above the measured one, and the stated range ends above it.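

In this assay, methoxy in place of methyl on the benzyl group gives a 9.0-fold lower number from compound 3 to compound 4 (0.95 log units; beyond the scatter), while 4-methoxybenzyl in place of the amide hydrogen gives a 230-fold lower number from compound 2 to compound 4 (2.36 log units; beyond the scatter). The same change compares across the two cores as follows: the same change on two cores in this assay, an at least 1.4-fold lower number (0.15 log units; that floor lies within the scatter) from compound 1 to compound 2 and a 9.0-fold lower number (0.95 log units; beyond the scatter) from compound 3 to compound 4; the limit leaves it open whether they differ. Compound 1 gives only a limit, > 10000 nM, and the compounds do not show whether the change has the same size on both cores.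

Still open, as far as these compounds go, is how a chloro or a nitrile would read in place of the methoxy on the benzyl group. From the compounds shown here alone, a longer chain in place of the benzyl group, or an amine or a carboxylic acid on it, also remains open in this assay.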